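Shortening an Isobutyl Chain in a Whole-Animal Inhibition Assay

This account rests on a few compounds, and the source may have more. Where it says the series, first, only, none or still open, it means among the compounds named here.

Of the compounds shown here, three have been measured in a functional assay for inhibition, with Rattus norvegicus as the target; on this read-out higher numbers stand for weaker inhibition and lower numbers for stronger inhibition. Compound 1 `CC(C)C/N=c1\c(O)c(O)\c1=N/Cc1ccc(C#N)cc1` gives 10200 nM, the lowest of the three numbers, though compound 2 `CC(C)(C)/N=c1\c(O)c(O)\c1=N/Cc1ccccn1` with 11500 nM and compound 3 `CCCC(=O)N(Cc1ccc(C#N)cc1)c1c(NC(C)C(C)(C)C)c(=O)c1=O` with 12200 nM both sit within the usual scatter of it, so no real order among them can be read. Compound 4 `CCC/N=c1\c(O)c(O)\c1=N/Cc1ccc(C#N)cc1` has not yet been measured. It differs from compound 1 in one place: hydrogen in place of methyl on a saturated chain carbon bound to two saturated chain carbons. Among the compounds with values here, no measured pair shows what such a removal does here, so the step is expected to be small, probably no larger than the scatter, in either direction. Compound 4 is therefore estimated at 12000 nM, with a range from 6000 nM to 25000 nM, which means an expected step of a 1.2-fold higher number from compound 1 to compound 4 (0.07 log units; within the scatter).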

Compound 4, half-maximal inhibitory concentration: 21900 nM
Beside the measured number, compound 4's estimate is 1.8-fold (0.26 log units) below it, within the range that was stated.
By their numbers in this assay, from the lowest: compounds 1, 2, 3 and 4 (each within the scatter of the next, the first and the last beyond it).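

In this assay, trimming the isobutyl chain to propyl gives a 2.1-fold higher number from compound 1 to compound 4 (0.33 log units; beyond the scatter) and so lies beyond the scatter, though the step is modest. Within the data shown here, this is the first change in a single place whose size can be read here, and it shows that this saturated chain carbon is not indifferent to losing one methyl. Nothing available explains the step.

From the compounds shown here alone, what a longer chain such as butyl would do at this place remains open. So does the effect of a cyclopropylmethyl group there.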